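Working notes: compound 2 towards compound 3

The compounds below may be only part of what the source reports. "The series", "measured", "known", "first", "only" and "open" are said of these compounds alone.

Measured so far in a functional assay on L1210 cells (Mus musculus) for antiproliferative activity, read by MTT assay; a lower number here means a stronger inhibitor, a higher number a weaker inhibitor:
- compound 1 `COc1cc(/C=N/NC(=O)c2cn(C3CC3)c3cc(N/N=C/c4cc(OC)c(OC)c(OC)c4)c(F)cc3c2=O)cc(OC)c1OC`: <= 25000 nM
- compound 2 `O=C(N/N=C/c1ccccc1O)c1cn(C2CC2)c2cc(N3CCNCC3)c(F)cc2c1=O`: <= 25000 nM

Compound 2 stands at <= 25000 nM in this assay, and this is a limit, not a number. Compound 1 also gives only a limit, <= 25000 nM, so neither compound offers a measured number. The set as a whole reads: the limit of <= 25000 nM in this assay, at which 2 of the 2 values shown sit.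

Compound 3 `O=C(N/N=C/c1ccccc1[N+](=O)[O-])c1cn(C2CC2)c2cc(N3CCNCC3)c(F)cc2c1=O` is still to be measured. It differs from compound 2 by nitro in place of hydroxy on an aromatic carbon, the change from 2-hydroxyphenyl to 2-nitrophenyl, ortho to a large group (nitro in place of hydroxy on an aromatic carbon). Among the compounds with values here, the series holds no step between measured compounds, so nothing measured sizes this change. In this assay a step no larger than the usual scatter is expected, with no direction favoured. The only anchor for this expectation is compound 2 at its limit of <= 25000 nM, which gives no number to step from. The estimated change is a step that the limit leaves unreadable from compound 2 to compound 3, and it is an expectation only. Compound 3 is expected at 12000 nM, with an estimated range from 3000 nM to 25000 nM.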

Compound 3, half-maximal inhibitory concentration: <= 25000 nM
Compound 3 gave a limit, no number; the forecaster's own chance of this, stated with the estimate: 50%; the middle value lies beyond the limit too.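

No step can be read from compound 2 to compound 3 in this assay, since each gives only a limit and no number: the limit of <= 25000 nM in this assay, at which 3 of the 3 values shown sit.

The compounds shown leave open the size and the direction of any difference that comes with the change from 2-hydroxyphenyl to 2-nitrophenyl.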